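From carboxy to cyano: how much solubility remains?

This account rests on a few compounds, and the source may have more. Where it says the series, first, only, none or still open, it means among the compounds named here.

Going by the values given here, in a physicochemical assay for solubility, read by nephelometry, in phosphate buffer, measured as kinetic solubility, at pH 6.5 (on this read-out lower numbers stand for lower solubility and higher numbers for higher solubility), compound 2 (`O=C(Nc1ccc(C(=O)O)cc1)Nc1ccc(F)c(C(F)(F)F)c1`) gives 12.5 ug/mL as the only true number so far. Compound 1 (`CC(=O)c1ccc(NC(=O)Nc2ccc(F)c(C(F)(F)F)c2)cc1`) gives < 1.6 ug/mL in this assay and that reading is a limit of the assay, not a number.

Compound 3 (`N#Cc1ccc(NC(=O)Nc2ccc(F)c(C(F)(F)F)c2)cc1`) has not been measured yet. It keeps the core of compound 2 but carries cyano in place of carboxy on an aromatic carbon, para to a large group (cyano in place of carboxy on an aromatic carbon). Like compound 1, it therefore has no carboxy group.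

Among the compounds with values here, only one measured step bears on this change. It shows an at least 7.8-fold higher number from compound 1 to compound 2 (0.89 log units; beyond the scatter) as hydroxy takes the place of methyl on a carbonyl carbon, which creates the carboxy group that compound 3 lacks. Read in reverse, that step points to a fall in this assay beyond the scatter, though the new group differs from the methyl ketone of compound 1. The expected change is a 6.3-fold lower number from compound 2 to compound 3 (0.80 log units; beyond the scatter) and the assay may well report only a limit. For compound 3 the estimate is 2 ug/mL with an expected range from 1 ug/mL to 5 ug/mL in this read-out.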

Compound 3, solubility: < 1.6 ug/mL
Compound 3: a limit, no number; the forecaster's own chance of this, stated with the estimate: 55%; at least 1.2-fold (0.09 log units) between middle value and limit.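

In this assay compound 3 gives < 1.6 ug/mL, which is a limit of the assay and not a number. Cyano in place of carboxy on this aromatic carbon gives an at least 7.8-fold lower number from compound 2 to compound 3 (0.89 log units; beyond the scatter), so the fall is no longer tied to the acetyl group of compound 1: among the compounds shown, two different groups without carboxy at this place both end at the limit, and only compound 2, with carboxy, gives a true number. The step between compound 1 and compound 3 cannot be read, and acetyl and cyano cannot be ranked against each other, because both compounds stop at the same floor of the read-out: the limit of < 1.6 ug/mL in this assay, at which 2 of the 3 values shown sit.

From the compounds shown here alone, how far compound 1 and compound 3 lie under that floor remains unknown, and so does the true size of the fall from carboxy. Going by these compounds alone, it also remains open whether carboxy is the only group at this place that lifts the reading to a true number, or whether an amine or a primary amide on the same aromatic carbon of the shared core would do so as well.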